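The compounds below may be only part of what the source reports. "The series", "measured", "known", "first", "only" and "open" are said of these compounds alone.

Working notes on the series.

Three members of this set have been run in an ADME assay on U-937 cells (Homo sapiens) for cytotoxicity, read by MTT assay, with a stated time of 24 h, tested at 40 uM; on this read-out higher numbers stand for a weaker effect at the one concentration tested and lower numbers for a stronger effect. Compound 1 `CCCCCc1cc(O)cc(O)c1Oc1cc(OC)cc(C(=O)CCCC)c1C(=O)OC` gives 85% in this assay. Compound 2 `CCCCCc1cc(O)cc(O)c1Oc1cc2c(cc1OC)C(O)(CCCC)OC2=O` gives 122% in this assay. Compound 3 `CCCCCc1c(Oc2cc3c(cc2OC)C(CCCC)(OC)OC3=O)c(O)cc(O)c1C(=O)O` gives 121% in this assay, which places it as the second highest of the three numbers: its nearest neighbour is compound 2, whose number lies higher by an amount inside the usual scatter, and its furthest is compound 1, whose number lies lower by an amount beyond the scatter. None of the three points to a strong effect at the single concentration used.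

The next compound follows from compound 3 by one change. Compound 4 `CCCCCc1cc(O)cc(O)c1Oc1cc2c(cc1OC)C(CCCC)(OC)OC2=O` differs from compound 3 as follows: hydrogen in place of carboxy on an aromatic carbon. For the measured compounds named here, no pair of measured compounds differing in this one place is available, so the step cannot be read off a neighbouring pair.

Given that compound 3 sits at 121% and compound 2 at 122%, the step in this assay is expected to be small, in no settled direction and not beyond the scatter: a number 6 percentage points lower from compound 3 to compound 4 (within the scatter). Compound 4 is therefore estimated at 115% in this assay, with a range from 95% to 135%.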

Compound 4, a percentage reported as activity, at one concentration (the size of the read-out at that concentration, not a potency): 87%
The estimate for compound 4 lay 28 percentage points above the measured number; measured number below the stated range.
By their numbers in this assay, from the lowest: compounds 1 and 4 (each within the scatter of the next); then compounds 3 and 2 (each within the scatter of the next).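

In this assay, this aromatic carbon, ortho to a hydroxy group and ortho to a pentyl group, proves sensitive to substitution: hydrogen in place of carboxy gives a number 34 percentage points lower from compound 3 to compound 4 (beyond the scatter). The oxygen on the saturated carbon also matters, as methyl in place of hydrogen there gives a number 35 percentage points lower from compound 2 to compound 4 (beyond the scatter), so compound 4 is set apart from compound 2 and compound 3 by a single change in each case, made in two different places. No measurement in hand accounts for either step.

The compounds shown leave open whether a methyl ester, a primary amide or a nitrile on this aromatic carbon would read like carboxy or like hydrogen, and whether an ethyl or longer alkyl group on the oxygen on the saturated carbon would read like methyl or like hydrogen. They also leave open how the two changes combine, since the step for each is read only against compound 4, and how the read-out would run at other concentrations.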